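This account rests on a few compounds, and the source may have more. Where it says the series, first, only, none or still open, it means among the compounds named here.

Measured so far:
- compound 1, `CCCC(O)(C#Cc1ccc(C(CC)(CC)C2=CN(CC)C(C(=O)NCCN(CC)CC)C2)cc1C)CCC`: 1290 nM
- compound 2, `CCN(CC)CCNC(=O)C1CC=C(C(CC)(CC)c2ccc(C#CC(C)(O)CC)c(C)c2)N1CC`: 600 nM

These two compounds were tested in a functional assay on MCF7 cells (Homo sapiens) for antiproliferative activity, read by MTT assay, with a stated time of 24 h; on this read-out higher numbers stand for weaker inhibition and lower numbers for stronger inhibition. Of the two numbers, compound 1 has the higher one, so it is the weaker inhibitor of the pair; compound 2 gives a lower number, and the gap between them lies beyond the usual scatter of repeated measurements. For the measured compounds named here, the two compounds share the same core and differ only in the group at the far end of the triple bond, but no single-point step between them has been worked out, so the two values can only be set side by side.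

The compound now in question is compound 3, `C#Cc1ccc(C(CC)(CC)C2=CN(CC)C(C(=O)NCCN(CC)CC)C2)cc1C`. It comes from compound 1 by one change: a hydrogen atom in place of a group of 8 heavy atoms (7 carbon, 1 oxygen; no ring), on a triple-bonded carbon. The whole group at the end of the triple bond is removed, leaving a bare terminal alkyne.

Going by the values given here, no measured step of this kind is available, so the expectation rests on the two values alone. For compound 3 a modest move toward a higher number in this assay is expected, or none beyond the scatter, so the step of a 1.2-fold higher number from compound 1 to compound 3 (0.09 log units; within the scatter) is estimated to be small. The estimate for compound 3 is 1600 nM, with a range from 450 nM to 6000 nM.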

Compound 3, half-maximal inhibitory concentration: > 50000 nM
Compound 3 was reported as a limit; the forecaster's own chance of this, stated with the estimate: 5%; middle value at least 31-fold (1.49 log units) from the limit.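

Removing the whole group of 8 heavy atoms from the triple-bonded carbon gives an at least 38-fold higher number from compound 1 to compound 3 (1.58 log units; beyond the scatter) in this assay, so the bare terminal alkyne is far weaker here than the substituted one in compound 1. Compound 1 and compound 2 both carry a group containing oxygen at this place, so neither of them could show what happens when the triple bond ends in a hydrogen atom. Compound 3 gives > 50000 nM, which is a limit of the assay and not a number: the limit of > 50000 nM in this assay, at which 1 of the 3 values shown sits.

With only the whole group taken away in one step, the compounds shown leave open whether the oxygen, the carbon chains or both are what matter, and a simple methyl group, a chain without oxygen, an amine or a carboxylic acid at the same place would help to separate these. On these data alone, it also remains open whether the same removal would give a step of similar size from compound 2, whose group at this place is smaller and whose core differs from that of compound 1.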